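The compounds below may be only part of what the source reports. "The series", "measured", "known", "first", "only" and "open" are said of these compounds alone.

Three compounds share one five-membered core and were tested in a functional assay on the whole organism with Mus musculus as the target, in the maximal electroshock model, with a stated time of 0.5 h; a higher number here means that more compound is needed for the effect, a lower number that less compound is needed. Compound 1, `CC[C@]1(c2ccccc2)OC(=O)NC1=O`, gives 91 mg/kg. Compound 2, `CC[C@]1(c2ccccc2)OC(=O)N(C)C1=O`, gives 122 mg/kg. Compound 3, `CC[C@@]1(c2ccccc2)OC(=O)NC1=O`, gives 141 mg/kg. Compound 2 differs from compound 1 in one way: methyl in place of hydrogen on an amide-type nitrogen in a ring, and that change made a 1.3-fold higher number from compound 1 to compound 2 (0.13 log units; within the scatter). The core of compound 3 differs from the core of compound 1 only as follows: the two compounds have the same atoms and bonds and differ only in configuration as drawn: 1 of 1 stereo elements differ; a stereocentre at a saturated ring carbon is drawn R in compound 1 and S in compound 3; this pair made a 1.5-fold higher number from compound 1 to compound 3 (0.19 log units; within the scatter), and the comparison rests on (the fact that compounds 1 and 3 differ only in the configuration as drawn). All three values therefore lie within the usual scatter of one another, so no order among them can be claimed.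

Compound 4, `CC[C@@]1(c2ccccc2)OC(=O)N(C)C1=O`, has not yet been measured. It differs from compound 3 as follows: methyl in place of hydrogen on an amide-type nitrogen in a ring. The place is described in exactly the same words as for the pair of compound 1 and compound 2, so this is the same change on the other core. Resting on the earlier step of a 1.3-fold higher number from compound 1 to compound 2 (0.13 log units; within the scatter), the step is expected to be a 1.3-fold higher number from compound 3 to compound 4 (0.11 log units; within the scatter). Compound 4 is thus estimated at 180 mg/kg, with a likely range from 110 mg/kg to 300 mg/kg.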

Compound 4, dose for half-maximal effect: 188 mg/kg
Compound 4: the middle estimate sits 1.0-fold (0.02 log units) below what was measured; the measured number falls inside the stated range.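

In this assay, the same methyl-for-hydrogen swap on the amide-type nitrogen gives a 1.3-fold higher number from compound 3 to compound 4 (0.12 log units; within the scatter), and it can be set beside the earlier step: the same change on two cores in this assay, a 1.3-fold higher number (0.13 log units; within the scatter) from compound 1 to compound 2 and a 1.3-fold higher number (0.12 log units; within the scatter) from compound 3 to compound 4, 1.0-fold (0.00 log units) apart, within the scatter of two such steps

The two methyl compounds, which differ only at the stereocentre, give a 1.5-fold higher number from compound 2 to compound 4 (0.19 log units; within the scatter), a comparison that rests on this: the fact that compounds 2 and 4 differ only in the configuration as drawn

Going by these compounds alone, these steps all lie within the scatter, so the match shows only that the swap stays within the scatter on both cores; it does not show that methyl has a real effect of a shared size, and two cores cannot establish a rule for the wider series.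

The compounds shown leave open how this assay would read with a longer chain or a carboxylic acid on that nitrogen. They also leave open whether a longer chain in place of the ethyl group would give steps beyond the scatter.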